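From Methyl to Ethyl: What Compound 4 Might Show

A few compounds are considered here, and "the series" means these few. Any claim that something is new, unique, unknown or untested is made for them only; others in the source may bear on it.

Measured so far in an assay on NIH3T3 cells with Urotensin-2 receptor (Homo sapiens) as the target; a higher number here means that more compound is needed for the effect, a lower number that less compound is needed:
compound 1 `Cc1ccccc1C(=O)OC(CCN(C)C)c1ccc(Cl)cc1` gives 1700 nM
compound 2 `CN(C)CCC(OC(=O)c1ccc(-c2ccccc2)cc1)c1ccc(Cl)cc1` gives 525 nM
compound 3 `CN(C)CCC(OC(=O)c1ccc2ccccc2c1)c1ccc(Cl)cc1` gives 2090 nM

Compound 1 stands second highest of the three numbers in this assay. Its nearest neighbour is compound 3, which lies slightly above it but within the scatter, so no order can be read between the two. Compound 2 gives the lowest number, and its gap to compound 1 is beyond the scatter.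

Compound 4 `CCc1ccccc1C(=O)OC(CCN(C)C)c1ccc(Cl)cc1` has not yet been measured. It differs from compound 1 by methyl in place of hydrogen on a saturated chain carbon bound to an aromatic carbon: a methyl in place of hydrogen on a saturated chain carbon bound to an aromatic carbon, so that methyl becomes ethyl and 2-methylphenyl becomes 2-ethylphenyl. Going by the values given here, none of the measured pairs carries this change, so nothing in the data sets its size. The step of a 1.1-fold lower number from compound 1 to compound 4 (0.05 log units; within the scatter) is therefore expected to stay within the scatter, with no clear direction. Compound 4 is expected to give about 1500 nM in this assay, within a range from 600 nM to 4000 nM.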

Compound 4, half-maximal effective concentration: 1290 nM
Compound 4: middle estimate off by 1.2-fold (0.07 log units), on the high side; measured number inside the range.
By their numbers in this assay, from the lowest: compound 2; then compounds 4, 1 and 3 (each within the scatter of the next).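

Going by these compounds alone, this is the first step in the set that can be read at this place: in this assay a methyl in place of hydrogen on a saturated chain carbon bound to an aromatic carbon, turning 2-methylphenyl into 2-ethylphenyl, gives a 1.3-fold lower number from compound 1 to compound 4 (0.12 log units; within the scatter). The added carbon therefore leaves the number unchanged within the scatter, so this one extension of the chain has no readable effect in this assay. The data offer no independent information that would explain this result.

The compounds shown leave open whether a longer chain such as propyl, or a branched group such as isopropyl, would also leave the number unchanged at this place. They also leave open whether a methoxy group or a chlorine atom there would give a step beyond the scatter.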